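A few compounds are considered here, and "the series" means these few. Any claim that something is new, unique, unknown or untested is made for them only; others in the source may bear on it.

Working notes on a small set of amide analogues sharing one core, read in an assay on HeLa cells for displacement of a labelled ligand from adenosine receptor A3 (Homo sapiens), read by scintillation counting, with a stated time of 180 min, tested at 10 uM; a lower number here means less inhibition, a higher number more inhibition at the concentration tested (going by the name of the read-out).

Compound 1 `COc1cc(Br)cc2cc(C(=O)NCCCO)c(=N)oc12` gives 23%. Compound 2 `CCC(CO)NC(=O)c1cc2cc(Br)ccc2oc1=N` gives 24%. Compound 3 `COCCNC(=O)c1cc2cc(Cl)ccc2oc1=N` gives 13%, the smallest of the three numbers, though the number for compound 1 lies within the scatter of it and only the number for compound 2 stands beyond the scatter. Within the data shown here, no pair among the measured compounds differs in a single place, so no measured step is available within this set.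

Compound 4 `CCC(CO)NC(=O)c1cc2cc(Cl)ccc2oc1=N` has not been measured. It differs from compound 3 in one place: 1-(hydroxymethyl)propyl in place of 2-methoxyethyl on an amide-type nitrogen. Compound 2 carries the same 1-(hydroxymethyl)propyl group on its amide-type nitrogen and gives 24%, which is the only anchor for the entering group; what a chloro against a bromo on the shared core does is not shown by any pair here.

On that basis the expected step is a number 7 percentage points higher from compound 3 to compound 4 (within the scatter), upward and of modest size, about at the edge of the scatter. Compound 4 is thus estimated at 20%, with a range from 8% to 32%.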

Compound 4, a percentage reported as inhibition, at one concentration (the size of the read-out at that concentration, not a potency): 0%
For compound 4 the middle estimate is 20 percentage points above the measured one; measured number outside the range, below it.
By their numbers in this assay, from the lowest: compound 4; then compounds 3, 1 and 2 (each within the scatter of the next, the first and the last beyond it).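

In this assay, 1-(hydroxymethyl)propyl in place of 2-methoxyethyl on an amide-type nitrogen, with chloro held on the shared core, gives a number 13 percentage points lower from compound 3 to compound 4 (beyond the scatter) and not the rise that compound 2 had suggested, so the entering group, with its hydrogen-bond donor, does not bring a higher number with it on this chloro core. Chloro in place of bromo on an aromatic carbon, with 1-(hydroxymethyl)propyl held on the amide-type nitrogen, gives a number 24 percentage points lower from compound 2 to compound 4 (beyond the scatter) and is the first measured sign in this set that the halogen matters, so the reading for an amide group on the bromo core does not carry over to the chloro core. Nothing on hand accounts for either step.

As far as these compounds go, whether 2-methoxyethyl would also respond to chloro in place of bromo remains open, so the two steps cannot yet be told apart as independent or linked. Also open, from the compounds shown here alone, is how an amine or a carboxylic acid on the chain at the amide-type nitrogen, or iodo in place of chloro on the aromatic carbon, would read.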